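The source may hold more compounds than are shown below. What is called first, only, known or untested is meant among the compounds shown, and "the series" means these compounds.

Three compounds have been measured in an assay (strain Sprague-Dawley) for inhibition of Amine oxidase [flavin-containing] A (Rattus norvegicus), read by spectrophotometry, with a stated time of 5 min; on this read-out lower numbers stand for stronger inhibition and higher numbers for weaker inhibition:

Compound 1 `CNC(=O)/C=C1/COc2cc(OS(=O)(=O)c3ccccc3)ccc21` gives 34 nM.
Compound 2 `CNC(=O)/C=C1/COc2cc(OS(=O)(=O)c3ccc(Cl)cc3)ccc21` gives 12 nM.
Compound 3 `CNC(=O)/C=C1/COc2c1ccc(OS(=O)(=O)c1ccccc1)c2C` gives 9.8 nM.

Compound 2 differs from compound 1 by chloro in place of hydrogen on an aromatic carbon, and this change gave a 2.8-fold lower number from compound 1 to compound 2 (0.45 log units; beyond the scatter). Compound 3 differs from compound 1 by methyl in place of hydrogen on an aromatic carbon, a change to the core itself, which gave a 3.5-fold lower number from compound 1 to compound 3 (0.54 log units; beyond the scatter). The values of compound 2 and compound 3 lie within the usual scatter of each other, so nothing separates them.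

Compound 4 `CNC(=O)/C=C1/COc2c1ccc(OS(=O)(=O)c1cccc(Cl)c1)c2C` has not been measured in this assay. It differs from compound 3 by chloro in place of hydrogen on an aromatic carbon. Within the data shown here, this is the same kind of change as the one from compound 1 to compound 2, but not the same: there the chloro sits para to a large group, here it sits meta to a large group, and the two cores differ as described by methyl in place of hydrogen on an aromatic carbon. Among the measured compounds shown here, only one earlier example of this change exists, so the expectation rests on a single step. The step from compound 3 to compound 4 is expected to be a 1.8-fold lower number from compound 3 to compound 4 (0.25 log units; within the scatter), somewhat smaller than the earlier one, resting on a 2.8-fold lower number from compound 1 to compound 2 (0.45 log units; beyond the scatter) with the changed place taken into account. Compound 4 is therefore estimated at 5.5 nM, likely between 2.5 nM and 12 nM.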

Compound 4, half-maximal inhibitory concentration: 24 nM
Estimate against measurement, compound 4: 4.4-fold (0.64 log units) below, outside the stated range (above it).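

In this assay, placing chloro on the phenyl ring of compound 3 gave a 2.4-fold higher number from compound 3 to compound 4 (0.39 log units; beyond the scatter). Set beside the earlier step, the same kind of change went in opposite directions on the two cores: the same change on two cores in this assay, a 2.8-fold lower number (0.45 log units; beyond the scatter) from compound 1 to compound 2 and a 2.4-fold higher number (0.39 log units; beyond the scatter) from compound 3 to compound 4, 6.9-fold (0.84 log units) apart, beyond the scatter of two such steps This shows that the outcome of adding chloro on one core cannot simply be carried over to the other in this series, but it does not show why: the two steps differ both in the core, which carries an extra methyl in compound 3 and compound 4, and in where the chloro sits, meta to a large group in compound 4 and at another place on the ring in compound 2.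

The compounds shown leave open which of those two differences matters, and a chloro placed as in compound 2 on the core of compound 3 would settle that. They also leave open how a fluoro, a methoxy or an amine on the phenyl ring would behave on either core.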